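Phenyl to Cyclopropyl on Two Related Cores

A few compounds are considered here, and "the series" means these few. Any claim that something is new, unique, unknown or untested is made for them only; others in the source may bear on it.

Compound 1 `O=C1Nc2c(ncn2Cc2ccccc2)C(C#Cc2ccccc2)N1Cc1ccccc1` gives 1.4 ug/mL in a functional assay on K562 cells (Homo sapiens), read by thymidine incorporation, with a stated time of 5 h; on this read-out lower numbers stand for stronger inhibition and higher numbers for weaker inhibition.
Compound 2 `O=C1Nc2c(ncn2Cc2ccccc2)C(C#CC2CC2)N1Cc1ccccc1` gives 1.6 ug/mL in this assay.
Compound 3 `O=c1nc2c(ncn2Cc2ccccc2)c(C#Cc2ccccc2)n1Cc1ccccc1` gives 1 ug/mL in this assay.

Compound 1 and compound 2 differ by one change, (cyclopropyl in place of phenyl on a triple-bonded carbon), and that change made a 1.1-fold higher number from compound 1 to compound 2 (0.06 log units; within the scatter). The core of compound 3 differs from the core of compound 1, but that difference is not broken down here; the two values of compound 1 and compound 3 lie close together. Compound 4 `O=c1nc2c(ncn2Cc2ccccc2)c(C#CC2CC2)n1Cc1ccccc1` differs from compound 3 by cyclopropyl in place of phenyl on a triple-bonded carbon, the same change as between compound 1 and compound 2, at the same place. Because a 1.1-fold higher number from compound 1 to compound 2 (0.06 log units; within the scatter) lay within the scatter, the step from compound 3 to compound 4 is expected to be small as well, about a 1.1-fold higher number from compound 3 to compound 4 (0.04 log units; within the scatter). Compound 4 is therefore estimated at 1.1 ug/mL, with a likely range from 0.5 ug/mL to 2.5 ug/mL.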

Compound 4, half-maximal inhibitory concentration: 0.4 ug/mL
Compound 4: middle estimate off by 2.8-fold (0.44 log units), on the high side; measured number outside the range, below it.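

Replacing phenyl with cyclopropyl on the triple-bonded carbon gave a 2.5-fold lower number from compound 3 to compound 4 (0.40 log units; beyond the scatter) in this assay, a clear step that the same change did not produce on the other core. The two results do not match: the same change on two cores in this assay, a 1.1-fold higher number (0.06 log units; within the scatter) from compound 1 to compound 2 and a 2.5-fold lower number (0.40 log units; beyond the scatter) from compound 3 to compound 4, 2.9-fold (0.46 log units) apart, beyond the scatter of two such steps This shows that, in this series, the effect of this change cannot simply be carried from one core to the other, but it rests on a single pair per core and does not show what about the cores sets the two steps apart.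

As far as these compounds go, it remains open whether a longer carbon chain or an amine in place of cyclopropyl on the triple-bonded carbon would also behave differently on the two cores.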